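From carboxy to acetamido: cytotoxicity held at a limit

A few compounds are considered here, and "the series" means these few. Any claim that something is new, unique, unknown or untested is made for them only; others in the source may bear on it.

Measured in an ADME assay on L929 cells (Mus musculus) for cytotoxicity, read by resazurin assay, with a stated time of 72 h; on this read-out lower numbers stand for stronger inhibition and higher numbers for weaker inhibition
- compound 1 `O=C(/C=C/c1ccc2c(c1)B(O)OC2)c1ccc([N+](=O)[O-])cc1` gives > 10 ug/mL
- compound 2 `Nc1ccc(C(=O)/C=C/c2ccc3c(c2)B(O)OC3)cc1` gives > 10 ug/mL
- compound 3 `O=C(O)c1ccc(C(=O)/C=C/c2ccc3c(c2)B(O)OC3)cc1` gives > 10 ug/mL

Compound 3 stands at > 10 ug/mL on this read-out, which is a limit and not a number. The set as a whole shows the limit of > 10 ug/mL in this assay, at which 3 of the 3 values shown sit, and so gives no exact value to start from.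

Compound 4 `CC(=O)Nc1ccc(C(=O)/C=C/c2ccc3c(c2)B(O)OC3)cc1` carries acetamido in place of carboxy on an aromatic carbon, para to a large group, and the count for this swap is acetamido in place of carboxy on an aromatic carbon as computed from the two structures.

Three measured swaps at this same place bear on the change. Each of a step that the two limits leave unreadable from compound 1 to compound 2 and a step that the two limits leave unreadable from compound 1 to compound 3 and a step that the two limits leave unreadable from compound 2 to compound 3 has no readable size, so no step beyond the scatter is expected in this assay in either direction. The expected outcome is a step that the limit leaves unreadable from compound 3 to compound 4 as estimated here.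

Compound 4 is estimated at 20 ug/mL with an expected range from 10 ug/mL to 50 ug/mL and will most likely be reported as a limit again.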

Compound 4, half-maximal inhibitory concentration: > 10 ug/mL
Compound 4 gave a limit, no number; the forecaster's own chance of this, stated with the estimate: 85%; the middle value is on the limit's open side.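

Compound 4 gives > 10 ug/mL, which is a limit and not a number. No step to compound 4 from compound 1, compound 2 or compound 3 can be read, as all four share one limit: the limit of > 10 ug/mL in this assay, at which 4 of the 4 values shown sit.

These compounds leave open what exact value any of them has in this assay, and whether swapping nitro, amino, carboxy or acetamido changes it at all.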